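A Methoxyphenyl Swap on the Shared Core

The source may report more compounds than this note shows. Statements on the series, on what has been measured and on what is new or still open speak of the compounds shown alone.

For the measured compounds named here, compound 3 `O=CCN1N=C(c2ccc3ccccc3c2)CC1c1ccco1` gives 18000 nM in a functional assay on OVCAR cells (Homo sapiens) for cytotoxicity, read by sulforhodamine B assay, with a stated time of 48 h (on this read-out higher numbers stand for weaker inhibition and lower numbers for stronger inhibition), the second highest of the three numbers known. Compound 1 `O=CCN1N=C(c2ccc3ccccc3c2)CC1c1ccccc1` gives 21500 nM, and the step of a 1.2-fold lower number from compound 1 to compound 3 (0.08 log units; within the scatter) lies within the scatter. Compound 2 `COc1ccc(C2CC(c3ccc4ccccc4c3)=NN2CC=O)cc1OC`, however, gives 2450 nM, well below compound 3. Compound 4 `COc1ccc(C2CC(c3ccc4ccccc4c3)=NN2CC=O)cc1` differs from compound 3 by 4-methoxyphenyl in place of furan-2-yl on a saturated ring carbon. Going by the values given here, the only measured step at this position, a 1.2-fold lower number from compound 1 to compound 3 (0.08 log units; within the scatter), was within the scatter, but the values of compound 1 and compound 2 show that methoxy substitution on this ring is accompanied by a much lower number. A step of a 3.0-fold lower number from compound 3 to compound 4 (0.48 log units; beyond the scatter) beyond the scatter is therefore expected, downward. Compound 4 is estimated at 6000 nM, with a range from 2000 nM to 18000 nM.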

Compound 4, half-maximal inhibitory concentration: 5790 nM
For compound 4 the middle estimate is 1.0-fold (0.02 log units) above the measured one; low and high end bracket the measured number.
By their numbers in this assay, from the lowest: compound 2; then compound 4; then compounds 3 and 1 (each within the scatter of the next).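

The step (a 3.1-fold lower number from compound 3 to compound 4 (0.49 log units; beyond the scatter)) shows that in this assay this saturated ring carbon does respond to a change of group. Methoxy alone on the phenyl ring is enough to separate the numbers (a 3.7-fold lower number from compound 1 to compound 4 (0.57 log units; beyond the scatter)), and removing one methoxy from the two in compound 2 gives a smaller move the other way (a 2.4-fold higher number from compound 2 to compound 4 (0.37 log units; beyond the scatter)). Nothing available explains these steps. On these data alone, whether a hydroxy group or a chlorine atom on this phenyl ring would go with a similar fall stays open, as does whether a single methoxy elsewhere on the ring would match the 4-methoxyphenyl group.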